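The source may report more compounds than this note shows. Statements on the series, on what has been measured and on what is new or still open speak of the compounds shown alone.

Of the compounds shown here, three have so far been tested in a functional assay on ECa-109 cells (Homo sapiens) for inhibition, read by MTT assay, with a stated time of 72 h; on this read-out lower numbers stand for stronger inhibition and higher numbers for weaker inhibition. Compound 1 `CC(C)(C)OC(=O)N1CCN(C(=S)SCc2cn(-c3ccccc3F)nn2)CC1` reaches only a limit of the assay, > 128000 nM, not a number. Compound 2 `CC(C)(C)OC(=O)N1CCN(C(=S)SCc2cn(Cc3ccc(Cl)cc3)nn2)CC1` likewise gives only a limit, > 128000 nM. Going by the values given here, compound 3 `Cc1ccc(-n2cc(CSC(=S)N3CCN(C(=O)OC(C)(C)C)CC3)nn2)cc1` is the one compound with a real number: in this assay compound 3 gives 114000 nM, while the other two values sit at the limit of > 128000 nM in this assay, at which 2 of the 3 values shown sit. The measured steps are accordingly thin. The step of an at least 1.1-fold lower number from compound 1 to compound 3 (0.05 log units; that floor lies within the scatter) and the step of an at least 1.1-fold lower number from compound 2 to compound 3 (0.05 log units; that floor lies within the scatter) are both only floors, and the step that the two limits leave unreadable from compound 1 to compound 2 cannot be read at all. Compound 4 `COc1ccc(-n2cc(CSC(=S)N3CCN(C(=O)OC(C)(C)C)CC3)nn2)cc1` differs from compound 3 by methoxy in place of methyl on an aromatic carbon, which one bond further out reads as 4-methylphenyl to 4-methoxyphenyl. Among the compounds with values here, no measured step touches a change of this kind, so the expectation rests on compound 3 alone. Compound 4 is therefore expected to show a step of a 1.0-fold lower number from compound 3 to compound 4 (0.02 log units; within the scatter), nothing beyond the scatter. Compound 4 is estimated at 110000 nM, in the range from 40000 nM to 300000 nM.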

Compound 4, half-maximal inhibitory concentration: > 128000 nM
Compound 4 gave a limit, no number (the forecaster's own chance of this, stated with the estimate: 45%); middle value at least 1.1-fold (0.06 log units) away from the limit.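

Going by these compounds alone, the earlier compounds changed only the whole group on the aromatic nitrogen, whereas compound 4 is the first to change an aromatic carbon of the ring itself, para to a large group. In this assay, as far as these compounds go, methoxy in place of methyl gives an at least 1.1-fold higher number from compound 3 to compound 4 (0.05 log units; that floor lies within the scatter), so this change brings no sign of stronger inhibition, although the size of the step remains unknown. Compound 4 gives a limit and not a number, its steps to compound 1 and compound 2 cannot be read, and most of the series now rests at one value: the limit of > 128000 nM in this assay, at which 3 of the 4 values shown sit.

From the compounds shown here alone, how far compound 4 lies beyond its limit remains open. Also open, going by these compounds, is whether an amine, a carboxylic acid or a longer chain such as ethoxy at this ring carbon would bring inhibition clearly stronger than that of compound 3.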